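Trading the Benzothiophene Arm for a Short Propyl Chain

The compounds below may be only part of what the source reports. "The series", "measured", "known", "first", "only" and "open" are said of these compounds alone.

Compound 1 `Cc1cc(N2CC[C@@H](C)[C@@H](N(C)c3ncnc4[nH]ccc34)C2)n2nc(SCc3csc4ccc(Cl)cc34)nc2n1` was examined in a functional assay on BGC-823 cells (Homo sapiens) for inhibition, read by MTT assay, with a stated time of 72 h; on this read-out higher numbers stand for weaker inhibition and lower numbers for stronger inhibition. In this assay compound 1 gives only a limit of the assay, > 100000 nM. The nearest measured relative, compound 2 `Cc1cc(N2CC[C@@H](C)[C@@H](N(C)c3ncnc4[nH]ccc34)C2)n2nc(SCc3ccc(F)c(Cl)c3)nc2n1`, carries 3-chloro-4-fluorophenyl in place of 5-chloro-1-benzothiophen-3-yl on a saturated chain carbon bound to a sulfur; in this assay compound 2 gives 98900 nM. The step of a number no higher from compound 1 to compound 2 (the limit leaves the size open) cannot be sized because compound 1 sits at the limit of > 100000 nM in this assay, at which 1 of the 2 values shown sits.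

Compound 3 `CCCSc1nc2nc(C)cc(N3CC[C@@H](C)[C@@H](N(C)c4ncnc5[nH]ccc45)C3)n2n1` has not yet been measured. It differs from compound 1 by ethyl in place of 5-chloro-1-benzothiophen-3-yl on a saturated chain carbon bound to a sulfur. For the measured compounds named here, the only measured step touches the same saturated chain carbon bound to a sulfur, yet its size is unreadable, so it offers no scale for the new change. Both measured compounds sit at the upper edge of what this assay can resolve, and nothing in the data points toward a step beyond the scatter in either direction. Compound 3 is therefore estimated at 100000 nM, within 30000 nM to 300000 nM, which corresponds to an expected step of a number no higher from compound 1 to compound 3 (the limit leaves the size open).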

Compound 3, half-maximal inhibitory concentration: 51200 nM
Beside the measured number, compound 3's estimate is 2.0-fold (0.29 log units) above it; measured number inside the range.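

In this assay compound 1 gives only a limit of the assay, > 100000 nM. Ethyl in place of 5-chloro-1-benzothiophen-3-yl on a saturated chain carbon bound to a sulfur, a change that removes both aromatic rings and the chlorine, reads as an at least 1.9-fold lower number from compound 1 to compound 3 (0.29 log units; that floor lies within the scatter), and ethyl in place of 3-chloro-4-fluorophenyl at the same place reads as a 1.9-fold lower number from compound 2 to compound 3 (0.29 log units; within the scatter). Neither step goes beyond the scatter, so this first arm without a ring shows no separation from the two arms that carry rings, and the step between those two ring-bearing compounds still cannot be read, with the only bound on it being the limit: the limit of > 100000 nM in this assay, at which 1 of the 3 values shown sits.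

The compounds shown leave open whether any group at this place can move the number beyond the scatter, and how far compound 1 truly lies from compound 3. An amine or a carboxylic acid at the end of the propyl chain, or a chain longer than propyl on the sulfur, would be needed to show whether this position responds at all.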